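Trimming the carbamate of an imidazolyl integrin antagonist

The compounds below may be only part of what the source reports. "The series", "measured", "known", "first", "only" and "open" are said of these compounds alone.

Three compounds share a core and differ at the carbamate and the heterocycle. Compound 1 `COC(=O)N1C[C@@]2(CC(C(=O)NC[C@H](NS(=O)(=O)c3c(C)cc(C)cc3C)C(=O)O)=NO2)C[C@H]1CNc1nc2ccccc2[nH]1` gives 1.4 nM in a functional assay for antagonist activity at integrin alpha-5/beta-1 (Homo sapiens), read by ELISA; on this read-out higher numbers stand for weaker inhibition and lower numbers for stronger inhibition. Compound 2 `CCCCOC(=O)N1C[C@@]2(CC(C(=O)NC[C@H](NS(=O)(=O)c3c(C)cc(C)cc3C)C(=O)O)=NO2)C[C@H]1CNc1ncc[nH]1` gives 14 nM in this assay, and compound 3 `Cc1cc(C)c(S(=O)(=O)N[C@@H](CNC(=O)C2=NO[C@]3(C2)C[C@@H](CNc2ncc[nH]2)N(C(=O)OCc2cccnc2)C3)C(=O)O)c(C)c1` gives 39 nM. Compound 3 thus stands highest of the three, with compound 2 nearest and compound 1 furthest away. For the measured compounds named here, the one step is a 2.8-fold higher number from compound 2 to compound 3 (0.44 log units; beyond the scatter).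

Compound 4 `COC(=O)N1C[C@@]2(CC(C(=O)NC[C@H](NS(=O)(=O)c3c(C)cc(C)cc3C)C(=O)O)=NO2)C[C@H]1CNc1ncc[nH]1` differs from compound 3 by hydrogen in place of pyridin-3-yl on a saturated chain carbon bound to an oxygen next to a carbonyl group. Going by the values given here, no measured pair isolates this change: compound 1 carries the same methyl carbamate but also a different heterocycle, so its value shows only that a methyl carbamate can sit in a potent compound. The step of a 2.8-fold higher number from compound 2 to compound 3 (0.44 log units; beyond the scatter) suggests that removing the pyridin-3-yl group returns compound 4 toward the level of compound 2, though a methyl is shorter than the propyl there. Compound 4 is therefore expected to give about 15 nM in this assay, between 5 nM and 45 nM, meaning an estimated step of a 2.6-fold lower number from compound 3 to compound 4 (0.41 log units; beyond the scatter).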

Compound 4, half-maximal inhibitory concentration: 21 nM
Beside the measured number, compound 4's estimate is 1.4-fold (0.15 log units) below it; low and high end bracket the measured number.
By their numbers in this assay, from the lowest: compound 1; then compounds 2, 4 and 3 (each within the scatter of the next, the first and the last beyond it).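

With the methyl carbamate in place, the carbamate position looks less sensitive than the earlier step alone suggested: hydrogen in place of pyridin-3-yl gives a 1.9-fold lower number from compound 3 to compound 4 (0.27 log units; within the scatter) in this assay and hydrogen in place of propyl gives a 1.5-fold higher number from compound 2 to compound 4 (0.18 log units; within the scatter) in the same assay, so compound 4 cannot be separated from either neighbour. The heterocycle is the larger matter, since the same carbamate now isolates 1H-imidazol-2-yl in place of 1H-benzimidazol-2-yl on an amine nitrogen, and that change gives a 15-fold higher number from compound 1 to compound 4 (1.18 log units; beyond the scatter) as a step beyond the scatter. Nothing in the available data explains either result.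

As far as these compounds go, whether an amine, a carboxylic acid or a longer chain on the carbamate would shift the number remains open. So does whether 1H-benzimidazol-2-yl would have a similar effect alongside the propyl or pyridin-3-yl carbamates.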